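Cytotoxicity notes on the bridged diphenyl series, compound 4

This account rests on a few compounds, and the source may have more. Where it says the series, first, only, none or still open, it means among the compounds named here.

Measured so far in an ADME assay on L6 cells (Rattus norvegicus) for cytotoxicity, read by resazurin assay, with a stated time of 72 h; a lower number here means a stronger inhibitor, a higher number a weaker inhibitor:
compound 1 `O=C(CN1CCCC1)OC1CC2(N3CCCCC3)CC(c3ccccc3)C1C(c1ccccc1)C2`, compound 1 gives 16400 nM
compound 2 `O=C(CN1CCCCC1)OC1CC2(N3CCCC3)CC(c3ccccc3)C1C(c1ccccc1)C2`, compound 2 gives 14200 nM
compound 3 `CN(C)C12CC(OC(=O)CN3CCCC3)C(C(c3ccccc3)C1)C(c1ccccc1)C2`, compound 3 gives 32700 nM

Compound 1 has the second highest of the three numbers in this assay; its nearest neighbour is compound 2 and its furthest is compound 3, and the values of compound 1 and compound 2 show no difference beyond the scatter. Within the data shown here, the one single-site step among the measured compounds is a 2.0-fold higher number from compound 1 to compound 3 (0.30 log units; within the scatter), a change at the position carrying the piperidin-1-yl group.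

Compound 4 `CN1CCN(CC(=O)NC2CC3(N4CCCCC4)CC(c4ccccc4)C2C(c2ccccc2)C3)CC1` is not yet measured. Against compound 1 the change is (((4-methylpiperazin-1-yl)methyl)carbonyl)amino in place of (((pyrrolidin-1-yl)methyl)carbonyl)oxy on a saturated ring carbon. Among the measured compounds shown here, no measured step touches this position or this kind of exchange, so the step from compound 1 to compound 3 gives no direct guidance; all that the measured compounds show is that the numbers in this assay sit in a narrow band. The expectation for compound 4 is therefore a step of a 1.0-fold lower number from compound 1 to compound 4 (0.01 log units; within the scatter), that is, nothing beyond the scatter. Compound 4 is estimated at 16000 nM, within 6000 nM to 45000 nM.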

Compound 4, half-maximal inhibitory concentration: 57500 nM
Compound 4: the middle estimate sits 3.6-fold (0.56 log units) below what was measured; the whole stated range lies below it.
By their numbers in this assay, from the lowest: compounds 2, 1, 3 and 4 (each within the scatter of the next, the first and the last beyond it).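

In this assay, among these compounds, this saturated ring carbon gives the first single-site step beyond the scatter, a modest one (a 3.5-fold higher number from compound 1 to compound 4 (0.54 log units; beyond the scatter)), with (((4-methylpiperazin-1-yl)methyl)carbonyl)amino in place of (((pyrrolidin-1-yl)methyl)carbonyl)oxy. Among the compounds shown here, the only earlier step (a 2.0-fold higher number from compound 1 to compound 3 (0.30 log units; within the scatter)) lay within the scatter and concerned the position carrying the piperidin-1-yl group, so it said nothing about this position. The exchange changes the linking oxy to amino, the ring and the hydrogen-bond donor count together, and nothing at hand accounts for the step.

On these data alone, it remains open which part of the exchange carries the step: (((pyrrolidin-1-yl)methyl)carbonyl)amino on the core of compound 1 would separate the linkage from the ring. A plain primary amine on this carbon would show how the numbers stand without the side chain.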